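A few compounds are considered here, and "the series" means these few. Any claim that something is new, unique, unknown or untested is made for them only; others in the source may bear on it.

Measured compounds in a functional assay for inhibition of sodium/hydrogen exchanger (Oryctolagus cuniculus); a higher number here means a weaker inhibitor, a lower number a stronger inhibitor:
- compound 1 `Cc1cc(Cl)c(S(C)(=O)=O)cc1C(=O)N=C(N)N` gives 25 nM
- compound 2 `Cc1cc(OCc2ccccc2)c(S(C)(=O)=O)cc1C(=O)N=C(N)N` gives 28 nM
- compound 3 `Cc1cc(OC2CCCC2)c(S(C)(=O)=O)cc1C(=O)N=C(N)N` gives 27 nM

Among these three numbers compound 3 stands second highest, with compound 2 nearest and compound 1 furthest, both within the scatter of it. The three compounds share one core and differ only in the group on one aromatic carbon: chloro in compound 1, benzyloxy in compound 2, cyclopentyloxy in compound 3. The steps of a 1.1-fold higher number from compound 1 to compound 3 (0.03 log units; within the scatter) and a 1.0-fold lower number from compound 2 to compound 3 (0.02 log units; within the scatter) show that exchanging these three groups for one another leaves the read-out essentially unchanged.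

Compound 4 `Cc1ccc(S(C)(=O)=O)cc1C(=O)N=C(N)N` removes the group at that position altogether: hydrogen in place of cyclopentyloxy on an aromatic carbon. Going by the values given here, no measured step covers a change to hydrogen at this site, so the expectation rests on the indifference of the read-out to the three groups already tried. Among the compounds with values here, on that basis a step in this assay of no more than the scatter is expected, with the direction uncertain; the estimate allows a modest drift toward a higher number, since no compound without a group at this carbon has yet been seen. Compound 4 is therefore expected to give about 35 nM in this assay, within a range from 15 nM to 90 nM, corresponding to an expected step of a 1.3-fold higher number from compound 3 to compound 4 (0.11 log units; within the scatter).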

Compound 4, half-maximal inhibitory concentration: 150 nM
The estimate for compound 4 lay 4.3-fold (0.63 log units) below the measured number; measured number above the stated range.
By their numbers in this assay, from the lowest: compounds 1, 3 and 2 (each within the scatter of the next); then compound 4.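

In this assay, going by these compounds alone, this aromatic carbon, ortho to the methylsulfonyl group, proves not to be indifferent after all: the earlier compounds showed only that chloro, benzyloxy and cyclopentyloxy can replace one another, whereas leaving hydrogen there gives a 5.6-fold higher number from compound 3 to compound 4 (0.74 log units; beyond the scatter) and a 5.4-fold higher number from compound 2 to compound 4 (0.73 log units; beyond the scatter) and also a 6.0-fold higher number from compound 1 to compound 4 (0.78 log units; beyond the scatter). All three steps lie beyond the scatter and are close to one another in size, so compound 4 is the weakest inhibitor of the four, and a group on this carbon is favoured over hydrogen across a single chlorine atom and the much larger benzyloxy and cyclopentyloxy groups alike. Nothing available bears on what lies behind this difference, so the numbers give its size and no explanation.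

The compounds shown leave open how little is needed on this carbon, and whether fluoro, methoxy or a plain methyl group would give numbers like those of compound 1 or like that of compound 4. They also leave open whether an amine or a carboxylic acid at the same place would be tolerated as well as the three groups tried.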